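The source may hold more compounds than are shown below. What is called first, only, known or untested is meant among the compounds shown, and "the series" means these compounds.

Working notes on the series.

Compound 2 `CCC(CC)N1CCN(c2nc3c(c(Nc4ccc(C(F)(F)F)cc4)n2)CCN(c2ncccc2C(F)(F)F)CC3)CC1` gives 41 nM in a functional assay on HEK293 cells for antagonist activity at transient receptor potential cation channel subfamily V member 1 (Homo sapiens), read by FLIPR and calcium flux (a higher number here means a weaker inhibitor, a lower number a stronger inhibitor), the lowest number of the three measured. Compound 1 `NC1CCN(c2nc3c(c(Nc4ccc(C(F)(F)F)cc4)n2)CCN(c2ncccc2C(F)(F)F)CC3)C1` gives 3700 nM in this assay, and compound 3 `CC(C)(C)OC(=O)N1CCCC(Nc2nc3c(c(Nc4ccc(C(F)(F)F)cc4)n2)CCN(c2ncccc2C(F)(F)F)CC3)C1` gives 140 nM. Among the compounds with values here, the one step between neighbours that differ in a single place is a 90-fold lower number from compound 1 to compound 2 (1.96 log units; beyond the scatter); it exchanges the whole group on the aromatic carbon, so it speaks to the ring and its substituent together, not to the substituent alone.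

Compound 4 `FC(F)(F)c1ccc(Nc2nc(N3CCN(C4CCC4)CC3)nc3c2CCN(c2ncccc2C(F)(F)F)CC3)cc1` is the next member: cyclobutyl in place of pentan-3-yl on an amine nitrogen in a ring. Within the data shown here, no measured step varies only the group on the amine nitrogen of that ring, so there is nothing that bears on this change directly; the step into compound 2 shows only that this part of the molecule matters. A change of one carbon-free-of-heteroatoms group for another of similar size is expected to move the number little, within or near the scatter, with a slight lean toward a higher number. The expected step is a 1.7-fold higher number from compound 2 to compound 4 (0.23 log units; within the scatter). Compound 4 is therefore estimated at 70 nM, with a range of 25 nM to 200 nM.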

Compound 4, half-maximal inhibitory concentration: 24 nM
The estimate for compound 4 lay 2.9-fold (0.46 log units) above the measured number; measured number below the stated range.
By their numbers in this assay, from the lowest: compounds 4 and 2 (each within the scatter of the next); then compound 3; then compound 1.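

The step of a 1.7-fold lower number from compound 2 to compound 4 (0.23 log units; within the scatter) lies within the scatter, so on an amine nitrogen in a ring, cyclobutyl and pentan-3-yl cannot be told apart in this assay, despite the open chain giving way to a four-membered ring of carbon only. The step of a 150-fold lower number from compound 1 to compound 4 (2.19 log units; beyond the scatter) lies well beyond the scatter and is large, so a second substituted piperazine now stands far from the 3-aminopyrrolidin-1-yl of compound 1, which shows that the earlier large step was not tied to pentan-3-yl alone. Nothing available gives a reason for either step.

The compounds shown leave open how a methyl group, an acetyl group or a 2-hydroxyethyl chain on that amine nitrogen would read in this assay. They also leave open how the large steps divide between the ring and its substituent, as both change together in each.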